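A few compounds are considered here, and "the series" means these few. Any claim that something is new, unique, unknown or untested is made for them only; others in the source may bear on it.

Compound 1 `C=C(c1ccc(OC)cc1NC(=O)CNC)c1ccc(OC)c2c1OC(C)(C)C=C2` and compound 2 `C=C(c1ccc2c(c1)C=CC(C)(C)O2)c1ccc(OC)cc1NC(=O)CNC` carry the same (methylamino)methyl amide but rest on different cores; the difference between the two cores is not broken down here. In a functional assay on HeLa cells (Homo sapiens) for antiproliferative activity, read by MTT assay, with a stated time of 48 h (on this read-out lower numbers stand for stronger inhibition and higher numbers for weaker inhibition), compound 1 gives 310 nM, and in this assay compound 2 gives 410 nM; the two values lie within the scatter of each other. Compound 3 `C=C(c1ccc(OC)cc1NC(=O)CNCC)c1ccc(OC)c2c1OC(C)(C)C=C2` applies the change methyl in place of hydrogen on a saturated chain carbon bound to an amine nitrogen to the core of compound 1, and in this assay compound 3 gives 1090 nM. The resulting step is a 3.5-fold higher number from compound 1 to compound 3 (0.55 log units; beyond the scatter). Compound 4 `C=C(c1ccc2c(c1)C=CC(C)(C)O2)c1ccc(OC)cc1NC(=O)CNCC` applies the same change, (methyl in place of hydrogen on a saturated chain carbon bound to an amine nitrogen), to the core of compound 2. For the measured compounds named here, a step of similar size is expected here, a 3.4-fold higher number from compound 2 to compound 4 (0.53 log units; beyond the scatter), because the only measured instance of this change is a 3.5-fold higher number from compound 1 to compound 3 (0.55 log units; beyond the scatter). Compound 4 is therefore estimated at 1400 nM, with a likely range from 600 nM to 3300 nM.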

Compound 4, half-maximal inhibitory concentration: 1580 nM
Compound 4: middle estimate off by 1.1-fold (0.05 log units), on the low side, and the stated range covers the measured number.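

In this assay, going from methylamino to ethylamino on the core of compound 2 gives a 3.9-fold higher number from compound 2 to compound 4 (0.59 log units; beyond the scatter). This agrees with the step on the other core: the same change on two cores in this assay, a 3.5-fold higher number (0.55 log units; beyond the scatter) from compound 1 to compound 3 and a 3.9-fold higher number (0.59 log units; beyond the scatter) from compound 2 to compound 4, 1.1-fold (0.04 log units) apart, within the scatter of two such steps. On these two cores, then, the size of the step carries over, but two cores are a narrow base: the pair gives no assurance for any further core and offers no explanation of the loss.

The compounds shown leave open how a longer chain such as propylamino, a branched isopropylamino or a primary amine in place of methylamino would read on either core. As far as these compounds go, whether the step keeps its size for these groups also remains open.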